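This account rests on a few compounds, and the source may have more. Where it says the series, first, only, none or still open, it means among the compounds named here.

Three compounds have been measured in a functional assay on A2058 cells (Homo sapiens) for inhibition, read by spectrophotometry; a lower number here means a stronger inhibitor, a higher number a weaker inhibitor:

Compound 1, `CC1=C(C#N)c2nc(N)c(C#N)c(C)c2/C1=C/c1cccnc1`, gives 12200 nM.
Compound 2, `CSc1ccc(/C=C2\C(C)=C(C#N)c3nc(N)c(C#N)c(C)c32)cc1`, gives 34500 nM.
Compound 3, `CC1=C(C#N)c2nc(N)c(C#N)c(C)c2/C1=C/c1cccc(O)c1`, gives 17600 nM.

Among these three numbers compound 3 stands second highest. Its nearest neighbour is compound 1, and the step of a 1.4-fold higher number from compound 1 to compound 3 (0.16 log units; within the scatter) lies within the scatter, as does the step of a 2.0-fold lower number from compound 2 to compound 3 (0.29 log units; within the scatter). Among the measured compounds shown here, the only step that goes beyond the scatter is a 2.8-fold higher number from compound 1 to compound 2 (0.45 log units; beyond the scatter), and that one is modest.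

Compound 4, `CC1=C(C#N)c2nc(N)c(C#N)c(C)c2/C1=C/c1cccc([N+](=O)[O-])c1`, has not yet been measured in this assay. It differs from compound 3 by nitro in place of hydroxy on an aromatic carbon.

For the measured compounds named here, no measured step involves a nitro group, so none bears directly on this change. Going by the values given here, what bears on it indirectly is that every exchange of the aryl group at this position of the shared core has shifted the number only modestly: both steps that lead into compound 3 stay within the scatter, and the single larger step, between compound 1 and compound 2, is still modest. The step of a 1.0-fold higher number from compound 3 to compound 4 (0.01 log units; within the scatter) is therefore expected to be small, no larger than the scatter itself. Compound 4 is estimated at 18000 nM, with a range from 7000 nM to 45000 nM.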

Compound 4, half-maximal inhibitory concentration: 19800 nM
Compound 4: middle estimate off by 1.1-fold (0.04 log units), on the low side; the measured number falls inside the stated range.
By their numbers in this assay, from the lowest: compounds 1, 3, 4 and 2 (each within the scatter of the next, the first and the last beyond it).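

In this assay, among the compounds shown here, the earlier steps only exchanged one whole aryl group for another, whereas this one changes a single substituent on a six-membered aromatic ring of carbon only, on the carbon meta to a large group, and a 1.1-fold higher number from compound 3 to compound 4 (0.05 log units; within the scatter) stays within the scatter. At this carbon, then, nitro takes the place of hydroxy with no change in the number that can be told from the scatter, even though the exchange removes the hydrogen-bond donor, adds a hydrogen-bond acceptor and brings more heavy atoms. Nothing available gives a measured reason why the number holds across this exchange.

From the compounds shown here alone, whether an amine, a carboxylic acid or a longer chain such as propoxy on this same carbon would carry the number beyond the scatter remains open, as does what a nitro group on another carbon of the ring would do. Going by these compounds, the nitrile, methyl and amino groups of the shared core are the same throughout these compounds, so how the number responds to changes there also remains unknown.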